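Swapping the aryl amide: chlorophenyl to methylphenyl

The compounds below may be only part of what the source reports. "The series", "measured", "known", "first", "only" and "open" are said of these compounds alone.

Compound 3 `O=C(Nc1ccc(Cl)cc1)c1c(O)c2cccnc2n(-c2ccccc2)c1=O` gives 11.6% in a functional assay on the whole organism for inhibition, with Rattus norvegicus as the target, read by paw edema, at a dose of 100 mg/kg by the oral route; a lower number here means less inhibition, a higher number more inhibition at the dose given (going by the name of the read-out). Compound 1 `CNC(=O)c1c(O)c2cccnc2n(-c2ccccc2)c1=O` gives 9.6%, and compound 2 `COc1ccc(NC(=O)c2c(O)c3cccnc3n(-c3ccccc3)c2=O)cc1` gives 0.3%. The step of a number 11.3 percentage points higher from compound 2 to compound 3 (beyond the scatter) is the only one beyond the scatter, while a number 2 percentage points higher from compound 1 to compound 3 (within the scatter) and a number 9.3 percentage points lower from compound 1 to compound 2 (within the scatter) stay within it. Compound 4 `Cc1ccccc1NC(=O)c1c(O)c2cccnc2n(-c2ccccc2)c1=O` differs from compound 3 by 2-methylphenyl in place of 4-chlorophenyl on an amide-type nitrogen. For the measured compounds named here, no measured step changes the phenyl group in this way; the two steps that touch the amide-type nitrogen, a number 2 percentage points higher from compound 1 to compound 3 (within the scatter) and a number 9.3 percentage points lower from compound 1 to compound 2 (within the scatter), were both small. The expected step of a number 3.6 percentage points lower from compound 3 to compound 4 (within the scatter) is therefore within the scatter. For compound 4 the estimated value in this assay is 8%, with a range from 0% to 20%.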

Compound 4, a percentage reported as inhibition, in the whole organism at one dose (the size of the read-out at that dose, not a potency): 11.7%
Compound 4: the middle estimate sits 3.7 percentage points below what was measured; the range from low to high includes it.
By their numbers in this assay, from the lowest: compounds 2, 1, 3 and 4 (each within the scatter of the next, the first and the last beyond it).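

In this assay, a 2-methylphenyl on the amide-type nitrogen reads the same, within the scatter, as a 4-chlorophenyl (a number 0.1 percentage points higher from compound 3 to compound 4 (within the scatter)) and as a plain methyl (a number 2.1 percentage points higher from compound 1 to compound 4 (within the scatter)). Only the 4-methoxyphenyl group stands clearly apart from it (a number 11.4 percentage points higher from compound 2 to compound 4 (beyond the scatter)), so a second aryl group, this one with its substituent at a different ring position, now sits level with the chloro compound. Nothing measured here explains these readings. Still open, as far as these compounds go, is whether an amine or a carboxylic acid on this phenyl ring would raise the inhibition well beyond these values.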